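Aryl amide on the shared core: expectation for compound 4

The source may report more compounds than this note shows. Statements on the series, on what has been measured and on what is new or still open speak of the compounds shown alone.

Measured so far:
compound 1 `CC1CCCCC1C(=O)N1CC(c2nc(-c3cccc(F)c3)no2)C1` gives > 10000 nM
compound 2 `Cc1cccc(S(=O)(=O)N2CC(c3nc(-c4cccc(Cl)c4)no3)C2)c1` gives 390 nM
compound 3 `O=C(N1CCCCCC1)N1CC(c2nc(-c3cccc(Cl)c3)no2)C1` gives > 10000 nM

In an assay on HEK293 cells for negative allosteric modulation of metabotropic glutamate receptor 5 (Homo sapiens), read by FLIPR (on this read-out lower numbers stand for stronger inhibition and higher numbers for weaker inhibition), compound 1 reaches only a limit, > 10000 nM, and is not placed by a number. Compound 3 likewise stops at a limit, > 10000 nM. Compound 2 is the single entry with a measured number, 390 nM. Two of the three values thus sit at the limit of > 10000 nM in this assay, at which 2 of the 3 values shown sit.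

Compound 4 `O=C(c1ccc(F)cc1)N1CC(c2nc(-c3cccc(F)c3)no2)C1` differs from compound 1 by 4-fluorophenyl in place of 2-methylcyclohexyl on a carbonyl carbon. Within the data shown here, no measured pair shows a change of this kind, so the size of the step rests on expectation alone. The step from compound 1 to compound 4 is expected to be an at least 6.6-fold lower number from compound 1 to compound 4 (0.82 log units; beyond the scatter), toward stronger inhibition and beyond the scatter. Compound 4 is estimated at 1500 nM, with a range from 300 nM to 10000 nM.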

Compound 4, half-maximal inhibitory concentration: > 10000 nM
Compound 4 ended at the assay's limit; the forecaster's own chance of this, stated with the estimate: 30%; middle value at least 6.6-fold (0.82 log units) from the limit.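

No step can be read from compound 1 to compound 4, because both stop at a limit: the limit of > 10000 nM in this assay, at which 3 of the 4 values shown sit.

The compounds shown leave open whether 4-fluorophenyl in place of 2-methylcyclohexyl on a carbonyl carbon changes inhibition at all.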